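The source may hold more compounds than are shown below. What is called first, only, known or untested is meant among the compounds shown, and "the series" means these compounds.

Antiproliferative activity was measured in a functional assay on MDA-MB-231 cells (Homo sapiens) for antiproliferative activity, read by CCK-8 assay, with a stated time of 48 h (on this read-out lower numbers stand for stronger inhibition and higher numbers for weaker inhibition), for three compounds:

Compound 1 `Cc1[nH]c2ccccc2c1C1=C(Br)C(=O)C(c2c(C)[nH]c3ccccc23)=C(Br)C1=O` gives 5.55 ug/mL.
Compound 2 `Cc1ccc(-c2[nH]c3ccccc3c2C2=C(Br)C(=O)C(c3c(C)[nH]c4ccccc34)=C(Br)C2=O)cc1` gives 6.67 ug/mL.
Compound 3 `Cc1[nH]c2ccccc2c1C1=C(Cl)C(=O)C(c2c(-c3ccccc3)[nH]c3ccccc23)=C(Cl)C1=O` gives 4.46 ug/mL.

Compound 1 has the second highest of the three numbers, yet all three lie within the usual scatter of one another, so none can be called stronger or weaker than another on this evidence. Within the data shown here, the only single-point step is a 1.2-fold higher number from compound 1 to compound 2 (0.08 log units; within the scatter), a change on the other indole-type arm of the shared core, and it did not move the read-out beyond the scatter.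

Compound 4 `COc1ccc2[nH]c(C)c(C3=C(Br)C(=O)C(c4c(C)[nH]c5ccccc45)=C(Br)C3=O)c2c1` differs from compound 1 in one place: methoxy in place of hydrogen on an aromatic carbon. Among the measured compounds shown here, no measured pair in this set tests a substituent on that six-membered ring, so the change has no direct precedent here. For the measured compounds named here, the one comparison that does exist, the step from compound 1 to compound 2, shows that a change on the periphery of the core left this assay essentially unchanged. The step from compound 1 to compound 4 is therefore expected to be a 1.0-fold lower number from compound 1 to compound 4 (0.00 log units; within the scatter), with no shift beyond the scatter in either direction. The estimate for compound 4 is accordingly 5.5 ug/mL, with a range from 2.5 ug/mL to 12 ug/mL.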

Compound 4, half-maximal inhibitory concentration: > 10 ug/mL
Compound 4: only a limit was reported; the forecaster's own chance of this, stated with the estimate: 5%; at least 1.8-fold (0.25 log units) between middle value and limit.
By their numbers in this assay, from the lowest: compounds 3, 1 and 2 (each within the scatter of the next). At a limit, above all of these: compound 4.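

In this assay, compound 4 is the first of the compounds shown to be reported only as a limit rather than a number: the limit of > 10 ug/mL in this assay, at which 1 of the 4 values shown sits. The methoxy group on this six-membered aromatic ring gives an at least 1.8-fold higher number from compound 1 to compound 4 (0.25 log units; that floor lies within the scatter), so the floor alone does not separate the two compounds, and the real gap could be small or much larger. Among these compounds, this is still the first information on a substituent at this ring position, and it offers no sign that methoxy here gives a lower number than hydrogen.

As far as these compounds go, the true value of compound 4 stays open, so the size of the methoxy effect cannot be stated. Also open, from the compounds shown here alone, is how a different group at this carbon, such as fluorine, a hydroxyl or an amine, would compare with hydrogen and with methoxy.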